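A few compounds are considered here, and "the series" means these few. Any claim that something is new, unique, unknown or untested is made for them only; others in the source may bear on it.

Notes on the series. Among the measured compounds shown here, the set holds compound 1 `CCCCCc1cccc(NC(=O)NC(=O)CCl)c1`, compound 2 `CCNC(=O)NCc1ccc(C(C)(C)C)cc1`, compound 3 `O=C(CCCl)Nc1ccc(I)cc1` and compound 4 `C=CC(=O)NCc1ccc(C(C)(C)C)cc1`, which has no measurement yet. In a functional assay on MCF7 cells (Homo sapiens) for antiproliferative activity, with a stated time of 48 h (on this read-out lower numbers stand for stronger inhibition and higher numbers for weaker inhibition), compound 1 gives 8300 nM and compound 3 gives 26000 nM. For compound 2 this assay reports only a limit of > 100000 nM; this is the point (the limit of > 100000 nM in this assay, at which 1 of the 3 values shown sits). Compound 2 thus stands at the weak end of the numbers shown. The step to compound 4 is vinyl in place of ethylamino on a carbonyl carbon, which reads as ethylcarbamoyl to vinylcarbonyl. For the measured compounds named here, no measured step covers this change. Compound 4 is expected to move toward the measurable range, as compound 1 at 8300 nM and compound 3 at 26000 nM do. The step from compound 2 to compound 4 expected is an at least 4.0-fold lower number from compound 2 to compound 4 (0.60 log units; beyond the scatter). Compound 4 is estimated at 25000 nM, between 6000 nM and 100000 nM.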

Compound 4, half-maximal inhibitory concentration: > 100000 nM
Compound 4 was reported as a limit (the forecaster's own chance of this, stated with the estimate: 30%); at least 4.0-fold (0.60 log units) between middle value and limit.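

Compound 2 and compound 4 are both reported only as limits, so no step between them can be read: the limit of > 100000 nM in this assay, at which 2 of the 4 values shown sit.

The compounds shown leave open whether vinyl in place of ethylamino on a carbonyl carbon changes antiproliferative activity at all.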